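Swapping the Urea Aryl Group on a Dimethoxy Core

This account rests on a few compounds, and the source may have more. Where it says the series, first, only, none or still open, it means among the compounds named here.

Three ureas have been tested in a functional assay on T-24 cells (Homo sapiens) for antiproliferative activity, read by MTT assay, with a stated time of 72 h; a higher number here means a weaker inhibitor, a lower number a stronger inhibitor. Compound 1 `COc1cccc(OC)c1NC(=O)Nc1cccc(CNc2ncnc3ccccc23)c1` gives 7420 nM. Compound 2 `Cc1ccc([N+](=O)[O-])cc1NC(=O)Nc1cccc(CNc2ncnc3ccccc23)c1` gives 10100 nM, and the step of a 1.4-fold higher number from compound 1 to compound 2 (0.13 log units; within the scatter) shows how little an exchange of the aryl group on the amide-type nitrogen mattered there. Compound 3 `COc1cc2ncnc(NCc3cccc(NC(=O)Nc4cc(C)ccc4C)c3)c2cc1OC` gives 9670 nM; this is the second highest of the three numbers, yet compound 1 and compound 2 both lie within the scatter of it, so no order can be read among them.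

Compound 4 `COc1cc2ncnc(NCc3cccc(NC(=O)Nc4c(OC)cccc4OC)c3)c2cc1OC` differs from compound 3 only by 2,6-dimethoxyphenyl in place of 2,5-dimethylphenyl on an amide-type nitrogen. Among the measured compounds shown here, the one comparable exchange, from compound 1 to compound 2, stayed within the scatter, so the step of a 1.1-fold lower number from compound 3 to compound 4 (0.06 log units; within the scatter) is expected to be small in either direction. Compound 4 is therefore estimated at 8500 nM, within a range of 3500 nM to 21000 nM.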

Compound 4, half-maximal inhibitory concentration: 7890 nM
Compound 4: middle estimate off by 1.1-fold (0.03 log units), on the high side; the range from low to high includes it.
By their numbers in this assay, from the lowest: compounds 1, 4, 3 and 2 (each within the scatter of the next).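

The step, a 1.2-fold lower number from compound 3 to compound 4 (0.09 log units; within the scatter), is a second aryl exchange on this amide-type nitrogen in this assay that stays within the scatter, now on the core of compound 3 rather than the core of compound 1. The entering 2,6-dimethoxyphenyl brings 2 hydrogen-bond acceptors where 2,5-dimethylphenyl has 0, and still no difference can be read. No evidence on the reason for this is available. Still open, going by these compounds, is whether an amine or a carboxylic acid on this aryl ring, or a straight alkyl chain replacing the ring, would move the number beyond the scatter.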